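A New Arylamine Replaces Chlorophenyl on the Shared Core

The compounds below may be only part of what the source reports. "The series", "measured", "known", "first", "only" and "open" are said of these compounds alone.

compound 1 `CCC(c1nc2ncc(Cl)cc2[nH]1)[C@H]1CC[C@@H](c2ccnc3ccc(C(F)(F)F)cc32)CC1` — 2 nM
compound 2 `C[C@@H](c1nnc(-c2ccc(Cl)cc2)o1)[C@H]1CC[C@@H](c2ccnc3ccc(F)cc32)CC1` — 239 nM

In an assay on tissue (HeLa cells) for inhibition of Indoleamine 2,3-dioxygenase 1 (Homo sapiens), read by fluorescence, with a stated time of 18 h (a lower number here means a stronger inhibitor, a higher number a weaker inhibitor), compound 2 gives 239 nM, the highest of the two numbers measured. Going by the values given here, compound 1 gives 2 nM, a far lower number, and the gap between the two lies beyond the scatter, though the two structures differ in several places at once and no single-change step between measured compounds is available. Among the compounds with values here, compound 3 `COc1ccc(Nc2nnc([C@H](C)[C@H]3CC[C@@H](c4ccnc5ccc(F)cc54)CC3)o2)cc1` differs from compound 2 by (4-methoxyphenyl)amino in place of 4-chlorophenyl on an aromatic carbon, a change with no precedent among the measured pairs. With nothing to guide the size of the step, compound 3 is estimated at 150 nM, with a range from 40 nM to 600 nM. The expected step is a 1.6-fold lower number from compound 2 to compound 3 (0.20 log units; within the scatter), leaning toward a lower number but not beyond the usual scatter.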

Compound 3, half-maximal inhibitory concentration: 165 nM
The estimate for compound 3 lay 1.1-fold (0.04 log units) below the measured number; the range from low to high includes it.
By their numbers in this assay, from the lowest: compound 1; then compounds 3 and 2 (each within the scatter of the next).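

Going by these compounds alone, the change from 4-chlorophenyl to (4-methoxyphenyl)amino, on the aromatic carbon of the five-membered aromatic ring with 2 nitrogen and 1 oxygen, gives a 1.4-fold lower number from compound 2 to compound 3 (0.16 log units; within the scatter) in this assay and is the first single-place step available here. It shows that this position can take a group with more heavy atoms, carrying a hydrogen-bond donor and acceptors that 4-chlorophenyl lacks, without a step beyond the scatter. Nothing measured here accounts for this result.

Compound 3 brings in the amine link and the methoxy group together, so the compounds shown cannot separate their contributions; a (4-chlorophenyl)amino group would bear on that. Also open, on these data alone, is whether a carboxylic acid or a longer chain on the same carbon would move the number beyond the scatter.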